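Compound 2 to compound 4: methoxy in place of iodo

The source may hold more compounds than are shown below. What is called first, only, known or untested is meant among the compounds shown, and "the series" means these compounds.

In a functional assay on HL-60 cells (Homo sapiens) for cytotoxicity, read by MTT assay, with a stated time of 72 h (a lower number here means a stronger inhibitor, a higher number a weaker inhibitor), compound 1 (`Cc1ccc(S(=O)(=O)n2cc(COC3=C/C(=N\c4ccccc4)c4ccccc4C3=O)nn2)cc1`) gives 6710 nM and compound 2 (`Cc1ccc(S(=O)(=O)n2cc(COC3=C/C(=N\c4ccc(I)cc4)c4ccccc4C3=O)nn2)cc1`) gives 6310 nM while compound 3 (`Cc1ccc(S(=O)(=O)n2cc(COC3=C/C(=N\c4ccc(Br)cc4)c4ccccc4C3=O)nn2)cc1`) gives 4220 nM with all three numbers within the scatter of each other, so compound 2 holds no distinct place among them. Compound 4 (`COc1ccc(/N=C2\C=C(OCc3cn(S(=O)(=O)c4ccc(C)cc4)nn3)C(=O)c3ccccc32)cc1`) has methoxy in place of iodo on an aromatic carbon, para to a large group (methoxy in place of iodo on an aromatic carbon). The steps of a 1.1-fold lower number from compound 1 to compound 2 (0.03 log units; within the scatter) and a 1.6-fold lower number from compound 1 to compound 3 (0.20 log units; within the scatter) and a 1.5-fold lower number from compound 2 to compound 3 (0.17 log units; within the scatter) all stay within the scatter and exchange only hydrogen, iodo and bromo. For the measured compounds named here, no methoxy compound has been measured yet. In this assay the expected step is a 1.1-fold lower number from compound 2 to compound 4 (0.06 log units; within the scatter) and so none beyond the scatter. For compound 4 the estimate is 5500 nM with an expected range from 2500 nM to 12000 nM on present data.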

Compound 4, half-maximal inhibitory concentration: 6960 nM
Estimate against measurement, compound 4: 1.3-fold (0.10 log units) below; the measured number falls inside the stated range.
By their numbers in this assay, from the lowest: compounds 3, 2, 1 and 4 (each within the scatter of the next).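

In this assay the change from 4-iodophenyl to 4-methoxyphenyl adds an oxygen-bearing group to the hydrogen, iodo and bromo already read at this place, and the steps stay within the scatter: a 1.1-fold higher number from compound 2 to compound 4 (0.04 log units; within the scatter) and a 1.6-fold higher number from compound 3 to compound 4 (0.22 log units; within the scatter) and a 1.0-fold higher number from compound 1 to compound 4 (0.02 log units; within the scatter). These four compounds therefore give no separation among the groups at this position. Nothing available accounts for this result.

On these data alone, whether any group at this place moves the number beyond the scatter stays open. An amine, a carboxylic acid or a longer alkoxy chain would test this.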